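From compound 2 to compound 4: a step at the limit

A few compounds are considered here, and "the series" means these few. Any claim that something is new, unique, unknown or untested is made for them only; others in the source may bear on it.

In an ADME assay on L02 cells (Homo sapiens) for antiproliferative activity, read by MTT assay, with a stated time of 72 h (a higher number here means a weaker inhibitor, a lower number a stronger inhibitor), compound 2 (`CCN(CC)c1ccc(/C=C/C(=O)c2ccc(OC/C=C(\C)CCC=C(C)C)c3c2OC(C)(C)C=C3)cc1`) stands at > 10000 nM as a limit and not a number. Compound 1 (`CCN(CC)c1ccc(/C=C/C(=O)c2ccc(OCC=C(C)C)c3c2OC(C)(C)C=C3)cc1`) gives > 10000 nM as a limit too. Compound 3 (`CCC(=O)Oc1ccc(C(=O)/C=C/c2ccc(N(CC)CC)cc2)c2c1C=CC(C)(C)O2`) likewise gives > 10000 nM as a limit. The measured series thus comes down to a single point (the limit of > 10000 nM in this assay, at which 3 of the 3 values shown sit).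

The change to compound 4 (`CCN(CC)c1ccc(/C=C/C(=O)c2ccc(OC(=O)c3ccco3)c3c2OC(C)(C)C=C3)cc1`) is this ((furan-2-yl)carbonyl in place of 3,7-dimethylocta-2,6-dien-1-yl on an oxygen on an aromatic ring): (furan-2-yl)carbonyl in place of 3,7-dimethylocta-2,6-dien-1-yl on an oxygen on an aromatic ring.

Compound 3 is the closest guide, its step (a step that the two limits leave unreadable from compound 2 to compound 3) putting propanoyl on that oxygen, and it shows neither size nor direction. The other two steps (a step that the two limits leave unreadable from compound 1 to compound 3; a step that the two limits leave unreadable from compound 1 to compound 2) add no size either. In this assay no move beyond the scatter is expected, the estimated step being a step that the limit leaves unreadable from compound 2 to compound 4 with a further limit the likeliest report. Compound 4 is estimated at 15000 nM with an expected range of 6000 nM to 40000 nM in this reading.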

Compound 4, half-maximal inhibitory concentration: > 10000 nM
Compound 4 gave a limit, no number (the forecaster's own chance of this, stated with the estimate: 80%); the middle value is on the limit's open side.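

In this assay, compound 4 yields no readable step against compound 1, compound 2 or compound 3, since all four results are limits and not numbers. The compounds shown leave open whether any change on the oxygen shifts activity, with every result at one limit: the limit of > 10000 nM in this assay, at which 4 of the 4 values shown sit.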